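Cytotoxicity notes on aryl ester variation in the series

The source may hold more compounds than are shown below. What is called first, only, known or untested is meant among the compounds shown, and "the series" means these compounds.

Among the compounds with values here, compound 2 `COC(=O)c1ccc(C)cc1OC(=O)COc1cc(O)c2c(=O)cc(-c3ccccc3)oc2c1` is one of two compounds so far tested in an ADME assay on cells (T-cell, Mus musculus, strain BALB/c) for cytotoxicity, read by MTT assay, with a stated time of 48 h (on this read-out lower numbers stand for higher toxicity in this test and higher numbers for lower toxicity in this test), where compound 2 gives 250000 nM. Within the data shown here, compound 1 `COC(=O)c1c(F)cccc1OC(=O)COc1cc(O)c2c(=O)cc(-c3ccccc3)oc2c1` in this assay gives 319000 nM; the two values lie within the scatter of each other, as the single step shows: a 1.3-fold lower number from compound 1 to compound 2 (0.11 log units; within the scatter). Compound 3 `COC(=O)c1cc(O)ccc1OC(=O)COc1cc(O)c2c(=O)cc(-c3ccccc3)oc2c1` is not yet measured in this assay. It differs from compound 2 as follows: a group of 11 heavy atoms (8 carbon, 3 oxygen; one six-membered aromatic ring of carbon only) in place of a group of 11 heavy atoms (9 carbon, 2 oxygen; one six-membered aromatic ring of carbon only), on an oxygen next to a carbonyl group. Among the measured compounds shown here, the only step that bears on this change, from compound 1 to compound 2, also swaps one ring-bearing group of 11 heavy atoms for another on the same oxygen next to a carbonyl group, and it stayed within the scatter. No step beyond the scatter is therefore expected for compound 3 in this assay, so the estimated step is a 1.0-fold higher number from compound 2 to compound 3 (0.02 log units; within the scatter). The estimate for compound 3 is 260000 nM, with a range from 130000 nM to 520000 nM.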

Compound 3, half-maximal cytotoxic concentration: 263000 nM
For compound 3 the middle estimate is 1.0-fold (0.00 log units) below the measured one, within the range that was stated.
By their numbers in this assay, from the lowest: compounds 2, 3 and 1 (each within the scatter of the next).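

In this assay, the group entering on an oxygen next to a carbonyl group has 1 hydrogen-bond donor and the group leaving has 0 hydrogen-bond donors, and this exchange gives a 1.1-fold higher number from compound 2 to compound 3 (0.02 log units; within the scatter). Set against the fluorine-containing group of compound 1, the same group gives a 1.2-fold lower number from compound 1 to compound 3 (0.08 log units; within the scatter). The three ring-bearing groups thus lie within the scatter of one another, now including one with a hydrogen-bond donor, and no evidence at hand accounts for this.

As far as these compounds go, it remains open whether a ring carrying an amine or a carboxylic acid, or a longer chain in place of the ring, would also stay within the scatter in this assay. All three compounds share one core, so they give no reading of how changes to the core would affect these numbers.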